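From furan to hydroxypyridine: a single substitution step

The compounds below may be only part of what the source reports. "The series", "measured", "known", "first", "only" and "open" are said of these compounds alone.

Compound 2, `O=C(O)Cc1sc(C(c2ccc(F)cc2)c2ccc(F)cc2)nc1-c1ccoc1`: 130 nM
Compound 1, `COc1ccc(C(c2ccccn2)c2nc(-c3ccc(Cl)cc3)c(CC(=O)O)s2)cc1`: 310 nM

Both compounds were tested in an in vitro functional assay on HEK285-7 cells for antagonist activity at prostaglandin D2 receptor 2 (Homo sapiens), read by BRET and beta-arrestin recruitment; a lower number here means a stronger inhibitor, a higher number a weaker inhibitor. Of the two numbers, compound 2 has the lower one; compound 1 sits higher, and the gap between them is wider than the usual scatter of this assay, so compound 2 is the stronger of the pair on present evidence.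

The next compound, compound 3, `O=C(O)Cc1sc(C(c2ccc(F)cc2)c2ccc(F)cc2)nc1-c1ccnc(O)c1`, keeps everything of compound 2 except one ring: 2-hydroxypyridin-4-yl in place of furan-3-yl on an aromatic carbon. Within the data shown here, no measured pair in this set makes a change of this kind, so there is nothing to copy the direction or size from. The step is expected to be modest, plausibly toward a somewhat higher number, but not clearly beyond the scatter.

Compound 3 is therefore expected to come in around 250 nM, with a likely range from 80 nM to 800 nM. That estimate corresponds to an expected step of a 1.9-fold higher number from compound 2 to compound 3 (0.28 log units; within the scatter) in this assay.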

Compound 3, half-maximal inhibitory concentration: 890 nM
Compound 3: middle estimate off by 3.6-fold (0.55 log units), on the low side, and the stated range ends below it.
By their numbers in this assay, from the lowest: compound 2; then compound 1; then compound 3.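

This position, on an aromatic carbon next to the ring nitrogen, proves sensitive in this assay: putting 2-hydroxypyridin-4-yl in place of furan-3-yl brings a 6.8-fold higher number from compound 2 to compound 3 (0.84 log units; beyond the scatter), so this ring cannot be exchanged freely. The step changes several things at once. A six-membered aromatic ring replaces a five-membered one, the ring hetero atom is nitrogen rather than oxygen, and a hydroxyl group with its hydrogen-bond donor enters, so this single pair cannot show which of these matters. Nothing measured here explains why the number rose.

The compounds shown leave open whether the loss follows the hydroxyl group or the six-membered ring itself, a question that a plain pyridin-4-yl at this position could address. A methoxy group in place of the hydroxyl would further test whether the hydroxyl hydrogen matters.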